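Hydroxymethyl replacing ethylamino at the coumarin substituent

This account rests on a few compounds, and the source may have more. Where it says the series, first, only, none or still open, it means among the compounds named here.

Compound 3 `CCNc1cc(=O)oc2cc(OCc3cccc(Cl)c3)ccc12` gives 9330 nM in an assay on isolated protein (strain Sprague-Dawley) for inhibition of Amine oxidase [flavin-containing] A (Rattus norvegicus), read by spectrophotometry, with a stated time of 5 min (on this read-out higher numbers stand for weaker inhibition and lower numbers for stronger inhibition), and stands second highest of the three measured numbers. Compound 1 `NC(=O)COc1cc(=O)oc2cc(OCc3cccc(Cl)c3)ccc12` gives 24000 nM, compound 2 `Nc1cc(=O)oc2cc(OCc3cccc(Cl)c3)ccc12` gives 4170 nM. The steps at this position were a 5.8-fold lower number from compound 1 to compound 2 (0.76 log units; beyond the scatter), a 2.6-fold lower number from compound 1 to compound 3 (0.41 log units; beyond the scatter) and a 2.2-fold higher number from compound 2 to compound 3 (0.35 log units; beyond the scatter), so modest shifts. Compound 4 `O=c1cc(CO)c2ccc(OCc3cccc(Cl)c3)cc2o1` differs from compound 3 by hydroxymethyl in place of ethylamino on an aromatic carbon. Among the measured compounds shown here, no measured step swaps ethylamino for hydroxymethyl; the three steps show that changing a small group here moves the number only modestly, so compound 4 is expected to show a step of about a 1.0-fold lower number from compound 3 to compound 4 (0.02 log units; within the scatter) in this assay, not clearly beyond the scatter in either direction. Compound 4 is therefore estimated at 9000 nM, with a range from 3500 nM to 25000 nM.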

Compound 4, half-maximal inhibitory concentration: 10200 nM
Compound 4: middle estimate off by 1.1-fold (0.05 log units), on the low side; the measured number falls inside the stated range.
By their numbers in this assay, from the lowest: compound 2; then compounds 3 and 4 (each within the scatter of the next); then compound 1.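

In this assay hydroxymethyl and ethylamino cannot be told apart, with a 1.1-fold higher number from compound 3 to compound 4 (0.04 log units; within the scatter) here, so a nitrogen on this aromatic carbon is not required to reach this level. Amino still gives the lower number, with a 2.4-fold higher number from compound 2 to compound 4 (0.39 log units; beyond the scatter) for hydroxymethyl in its place, while a 2.4-fold lower number from compound 1 to compound 4 (0.37 log units; beyond the scatter) shows hydroxymethyl improving on carbamoylmethoxy. No measurement offered here explains these steps. Still open, going by these compounds, is how a carboxylic acid or a longer chain such as hydroxypropyl would read at this position, and whether dimethylamino would stay level with ethylamino.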